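Hydrazone aryl variation on the shared core: toward compound 4

This account rests on a few compounds, and the source may have more. Where it says the series, first, only, none or still open, it means among the compounds named here.

Three compounds of the series carry the same core and differ only in the hydrazone arm. Compound 1 `CCCSc1nc(N/N=C/c2ccc(C)cc2)c2nnn(Cc3ccccc3)c2n1` gives only a limit in a functional assay on MCF7 cells (Homo sapiens) for antiproliferative activity, read by MTT assay, with a stated time of 72 h (on this read-out higher numbers stand for weaker inhibition and lower numbers for stronger inhibition), namely > 64000 nM. Compound 2 `CCCSc1nc(N/N=C/c2ccc(Cl)cc2)c2nnn(Cc3ccccc3)c2n1` likewise gives only a limit in this assay, > 64000 nM. Among the measured compounds shown here, compound 3 `CCCSc1nc(N/N=C(\C)c2ccccc2O)c2nnn(Cc3ccccc3)c2n1` is the one member with a number in this assay, 11000 nM, and so it stands alone as the only quantified point. Compound 1 and compound 2 sit at a limit instead, as noted in the limit of > 64000 nM in this assay, at which 2 of the 3 values shown sit.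

The step from compound 1 to compound 3 reads as an at least 5.8-fold lower number from compound 1 to compound 3 (0.76 log units; beyond the scatter), and from compound 2 to compound 3 as an at least 5.8-fold lower number from compound 2 to compound 3 (0.76 log units; beyond the scatter). Both steps change the whole arm at once, so neither isolates the hydroxy.

Compound 4 `CCCSc1nc(N/N=C(\C)c2ccccc2)c2nnn(Cc3ccccc3)c2n1` is not yet measured. The change from compound 3 is hydrogen in place of hydroxy on an aromatic carbon. It moves the arm back toward the substitution pattern of compound 1 and compound 2, whose values are limits, so a weakening is expected, possibly beyond the reach of the assay. The expected step is a 3.2-fold higher number from compound 3 to compound 4 (0.50 log units; beyond the scatter) for compound 4. Compound 4 is therefore estimated at 35000 nM in this assay, with a range from 10000 nM to 100000 nM.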

Compound 4, half-maximal inhibitory concentration: 32100 nM
Beside the measured number, compound 4's estimate is 1.1-fold (0.04 log units) above it; low and high end bracket the measured number.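

Among the compounds shown here, the step in this assay, a 2.9-fold higher number from compound 3 to compound 4 (0.47 log units; beyond the scatter), is the first to isolate the hydroxy, since only 2-hydroxyphenyl to phenyl changes, and the loss on removing this group is modest, with compound 4 still giving a number rather than a limit. Against the other two arms, the floors of an at least 1.9-fold lower number from compound 2 to compound 4 (0.29 log units; that floor lies within the scatter) and an at least 1.9-fold lower number from compound 1 to compound 4 (0.29 log units; that floor lies within the scatter) do not show that compound 4 stands apart from compound 1 or compound 2, and each of these steps changes the arm in more than one feature. Compound 1 and compound 2 each remain at a limit, not a number: the limit of > 64000 nM in this assay, at which 2 of the 4 values shown sit.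

From the compounds shown here alone, it remains open whether an amine or a methoxy group, placed ortho to a large group as the hydroxy is in compound 3, would keep, lose or improve on the number of compound 3. Also open, going by these compounds, is whether a chloro or methyl group on the phenyl ring of compound 4 would shift the read-out, which would link this arm more directly to compound 1 and compound 2.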